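Taking the large group off compound 2

This account rests on a few compounds, and the source may have more. Where it says the series, first, only, none or still open, it means among the compounds named here.

In a functional assay on A549 cells (Homo sapiens) for antiproliferative activity, read by MTT assay, with a stated time of 72 h (a lower number here means a stronger inhibitor, a higher number a weaker inhibitor), compound 1 `CCCCCc1ccc(-c2cn(C[C@H](O)[C@H]3OC(=O)C(OCc4ccccc4)=C3OCc3ccccc3)nn2)cc1` gives 6220 nM, and compound 2 `Cc1ccc(S(=O)(=O)NCc2cn(C[C@H](O)[C@H]3OC(=O)C(OCc4ccccc4)=C3OCc3ccccc3)nn2)cc1` gives 16800 nM, the higher of the two numbers. Compound 3 `O=C1O[C@H]([C@@H](O)Cn2ccnn2)C(OCc2ccccc2)=C1OCc1ccccc1` has not been measured. Its change from compound 2 is hydrogen in place of (((4-methylphenyl)sulfonyl)amino)methyl on an aromatic carbon. Among the measured compounds shown here, one measured step bears on this carbon, a 2.7-fold higher number from compound 1 to compound 2 (0.43 log units; beyond the scatter), which is modest but beyond the scatter. On that single step, a further modest rise in this assay is expected, though support is thin. The expected change is a 1.8-fold higher number from compound 2 to compound 3 (0.25 log units; within the scatter). For compound 3 the estimated value is 30000 nM, with a range of 10000 nM to 100000 nM.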

Compound 3, half-maximal inhibitory concentration: > 100000 nM
Compound 3: only a limit was reported; the forecaster's own chance of this, stated with the estimate: 25%; at least 3.3-fold (0.52 log units) between middle value and limit.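

In this assay compound 3 gives > 100000 nM, which is a limit and not a number. With hydrogen on this aromatic carbon, the reading shows an at least 5.9-fold higher number from compound 2 to compound 3 (0.77 log units; beyond the scatter) and an at least 16-fold higher number from compound 1 to compound 3 (1.20 log units; beyond the scatter), so each of the two large groups gives a lower number than hydrogen does, and the step between those groups had not shown this. Both steps are floors, resting on a limit: the limit of > 100000 nM in this assay, at which 1 of the 3 values shown sits.

Going by these compounds, the true value of compound 3 stays open. So does whether a small group on this carbon, such as a methyl, a hydroxymethyl or an aminomethyl, would give a number near those of the large groups.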